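Chloro to iodo on a quinolone-type antiproliferative scaffold

This account rests on a few compounds, and the source may have more. Where it says the series, first, only, none or still open, it means among the compounds named here.

Compound 1 `COc1ccc(-c2cc(=O)c3c(OC)cc(OC)cc3n2Cc2ccccc2)cc1` was tested in a functional assay on UoC-B1 cells (Homo sapiens) for antiproliferative activity, with a stated time of 72 h; on this read-out higher numbers stand for an effect only at larger amounts of compound and lower numbers for an effect already at smaller amounts. In this assay compound 1 reaches only the limit of > 17300 nM, a boundary of the measurement rather than a number. Compound 2 `COc1ccc(-c2c(Cl)c(=O)c3c(OC)cc(OC)cc3n2S(=O)(=O)c2ccc(OC)cc2)cc1` carries a chloro group and a (4-methoxyphenyl)sulfonyl group on the shared core, yet in this assay compound 2 is recorded as "not determined" (no result reported), so no number places it among the values shown. Compound 3 `COc1ccc(-c2c(I)c(=O)c3c(OC)cc(OC)cc3n2S(=O)(=O)c2ccc(OC)cc2)cc1` differs from compound 2 by iodo in place of chloro on an aromatic carbon. For the measured compounds named here, no measured step exists for such a swap here, so any shift beyond the scatter remains uncertain. Compound 3 is therefore estimated at 3000 nM, within 300 nM to 20000 nM.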

Compound 3, half-maximal effective concentration: 2550 nM
Estimate against measurement, compound 3: 1.2-fold (0.07 log units) above, and the stated range covers the measured number.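

For the compounds shown here, compound 2 has no reported result in this assay, so no step from it to compound 3 can be read. From the compounds shown here alone, whether iodo in place of chloro on the shared core shifts the effect remains open.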